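Carboxypyridinyl to carboxyphenyl on the ring amine nitrogen

The compounds below may be only part of what the source reports. "The series", "measured", "known", "first", "only" and "open" are said of these compounds alone.

For the measured compounds named here, compound 2 `O=C(O)c1cncc(N2CC(O)(c3ccc(OCc4c(-c5c(Cl)cccc5Cl)noc4C4CC4)cc3Cl)C2)c1` is one of two compounds measured in an assay on isolated protein for agonist activity at Bile acid receptor (Homo sapiens), read by FRET; on this read-out lower numbers stand for smaller maximal responses and higher numbers for larger maximal responses. Compound 2 gives 102% in this assay. The other measured compound, compound 1 `CCO[C@]1(c2ccc(OCc3c(-c4c(Cl)cccc4Cl)noc3C3CC3)cc2Cl)C[C@H](c2cccc(C(=O)O)c2)C1`, gives 94% in this assay; the two numbers lie within the usual scatter of each other, so no order between them is claimed. Going by the values given here, no step between compounds that differ in a single place has been measured.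

Compound 3 `O=C(O)c1cccc(N2CC(O)(c3ccc(OCc4c(-c5c(Cl)cccc5Cl)noc4C4CC4)cc3Cl)C2)c1` is not yet measured. It differs from compound 2 by 3-carboxyphenyl in place of 5-carboxypyridin-3-yl on an amine nitrogen in a ring. Both measured compounds reach a maximal response close to the reference, and nothing measured so far suggests that the change shown alters this. The step of a number 4 percentage points lower from compound 2 to compound 3 (within the scatter) is therefore expected to stay within the scatter, in no particular direction. For compound 3 the expected value in this assay is 98%, with a range from 85% to 110%.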

Compound 3, largest response reached (reported as efficacy), in percent of the reference or control that the assay uses: 97%
Compound 3: the middle estimate sits 1 percentage points above what was measured; the measured number falls inside the stated range.
By their numbers in this assay, from the lowest: compounds 1, 3 and 2 (each within the scatter of the next).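

In this assay, for the compounds shown here, 3-carboxyphenyl in place of 5-carboxypyridin-3-yl on an amine nitrogen in a ring gives a number 5 percentage points lower from compound 2 to compound 3 (within the scatter), the only step that changes a single place. The change removes the hetero atom of the six-membered aromatic ring and one hydrogen-bond acceptor from the group, and the maximal response stays within the scatter, so at this position that ring nitrogen is not required to hold the response close to the reference. Nothing measured here gives a cause for this result.

The compounds shown leave open whether the carboxylic acid on this aromatic ring can give way to a primary amide or a tetrazole with the response preserved. They also leave open how a piperidine or a simple alkyl chain in place of the aromatic ring on this nitrogen would read in this assay.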